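Chroman series: replacing the chain substituent in compound 1

The source may hold more compounds than are shown below. What is called first, only, known or untested is meant among the compounds shown, and "the series" means these compounds.

In a functional assay (brain) for inhibition, with Rattus norvegicus as the target (on this read-out lower numbers stand for stronger inhibition and higher numbers for weaker inhibition), compound 1 `Cc1c(C)c2c(c(C)c1O)CCC(C)(CC(=O)[N-][N+](C)(C)C)O2` gives 6000 nM and stands lowest of the two numbers recorded, with compound 2 `Cc1c(C)c2c(c(C)c1O)CC[C@](C)(CC(=O)[N-][N+](C)(C)C)O2` nearest at 8000 nM; the pair lie within the scatter of each other, and the only point of difference is that (the fact that one of compounds 1 and 2 is drawn with a defined configuration and the other without, at the place where they differ). Among the measured compounds shown here, the sole measured step, a 1.3-fold higher number from compound 1 to compound 2 (0.12 log units; within the scatter), therefore carries no information about a change of substituent.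

Compound 3 `CSCCC1(C)CCc2c(C)c(O)c(C)c(C)c2O1` departs from compound 1 at a different place: a group of 3 heavy atoms (2 carbon, 1 sulfur; no ring) in place of a group of 7 heavy atoms (4 carbon, 2 nitrogen, 1 oxygen; no ring), on a saturated chain carbon bound to a saturated ring carbon. For the measured compounds named here, no measured step touches this position or this kind of exchange, so the direction of any effect in this assay cannot be read from the two numbers known. The expectation for compound 3 rests on compound 1 alone, at 6000 nM, and is set near it with a wide range to cover either outcome.

Compound 3 is estimated at 6000 nM, within 1500 nM to 25000 nM, which corresponds to an expected step of no change at the digits printed from compound 1 to compound 3 (within the scatter).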

Compound 3, half-maximal inhibitory concentration: 3000 nM
For compound 3 the middle estimate is 2.0-fold (0.30 log units) above the measured one; the measured number falls inside the stated range.
By their numbers in this assay, from the lowest: compounds 3, 1 and 2 (each within the scatter of the next, the first and the last beyond it).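

Notes on the place named as a saturated chain carbon bound to a saturated ring carbon: in this assay, putting (methylsulfanyl)methyl in place of the group of 7 heavy atoms gives a 2.0-fold lower number from compound 1 to compound 3 (0.30 log units; within the scatter), and this is the first reading of any change of substituent at this place. The earlier pair differed only in how one stereo element was drawn, whereas this step shows that a group with 3 heavy atoms, one of them sulfur and none of them nitrogen or oxygen, keeps the number within the scatter of compound 1, so the nitrogens and the carbonyl of the leaving group are not needed to obtain a number of this order. Nothing given here accounts for the size of this step.

With a single exchange at this place, the compounds shown do not tell whether a carboxylic acid, an amine or a longer alkyl chain would read the same way in this assay, or whether the sulfur itself matters compared with a plain carbon chain. They also leave open whether a defined configuration at the saturated ring carbon would alter the number for compound 3.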